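Swapping fluoro for trifluoromethyl on compound 1

The source may hold more compounds than are shown below. What is called first, only, known or untested is meant among the compounds shown, and "the series" means these compounds.

In a toxicity assay on Huh-7.5 cells (Homo sapiens) for inhibition, read by MTT assay, with a stated time of 96 h (on this read-out higher numbers stand for lower toxicity in this test and lower numbers for higher toxicity in this test), compound 1 `CN1CCN(Cc2ccc(NC(=O)c3ccc(OCCCCl)c(F)c3)cc2C(F)(F)F)CC1` gives 8800 nM. Compound 2 `CN1CCN(Cc2ccc(NC(=O)c3ccc(OCCCl)c([N+](=O)[O-])c3)cc2C(F)(F)F)CC1` gives 9040 nM, which lies within the usual scatter of the value for compound 1, so neither can be ranked above the other. Compound 3 `O=C(Nc1ccc(CN2CC(C(=O)O)C2)c(C(F)(F)F)c1)c1ccc(OCCCCl)c([N+](=O)[O-])c1` has only a limit, > 200000 nM, and not an exact number. Compound 1 therefore shares the toxic end of this small set with compound 2.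

Compound 4 `CN1CCN(Cc2ccc(NC(=O)c3ccc(OCCCCl)c(C(F)(F)F)c3)cc2C(F)(F)F)CC1` keeps the core of compound 1 but has trifluoromethyl in place of fluoro on an aromatic carbon, ortho to a 3-chloropropoxy group (trifluoromethyl in place of fluoro on an aromatic carbon). For the measured compounds named here, no measured pair shows this swap on its own, so the forecast is cautious. In this assay, no change beyond the scatter is expected, and the starting point is compound 1 at 8800 nM. The estimated step is a 1.3-fold lower number from compound 1 to compound 4 (0.10 log units; within the scatter), which would not stand out from the usual scatter. For compound 4, the expected value is 7000 nM, with an estimated range of 3500 nM to 14000 nM.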

Compound 4, half-maximal cytotoxic concentration: 13400 nM
Estimate against measurement, compound 4: 1.9-fold (0.28 log units) below; the measured number falls inside the stated range.
By their numbers in this assay, from the lowest: compounds 1, 2 and 4 (each within the scatter of the next). At a limit, above all of these: compound 3.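

In this assay, for the compounds shown here, the swap gives a 1.5-fold higher number from compound 1 to compound 4 (0.18 log units; within the scatter) and so offers the first single-change pair at this position, ortho to a 3-chloropropoxy group. On this pair, an aromatic carbon that carries fluoro in compound 1 can carry trifluoromethyl, a group with more heavy atoms, without a difference that stands out from the scatter. Nothing in the data shown gives a reason for this result.

One pair at one position cannot show whether other groups here would behave the same way, so it sets no general rule for this carbon. A nitrile or a methoxy group at this position, with the rest of compound 1 unchanged, would test whether the reading stays this flat across groups of other kinds.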